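Swapping a Nitrile for a Fluorine on a Pendant Ring

The source may report more compounds than this note shows. Statements on the series, on what has been measured and on what is new or still open speak of the compounds shown alone.

Measured compounds:
compound 1 `C[C@H]1CC[C@@H]2[C@@H](OC(=O)[C@]23CC(c2ccc(O)cc2)=NO3)[C@]2(C)C(=O)C=C[C@@]12O` gives 0.932
compound 2 `C[C@H]1CC[C@@H]2[C@@H](OC(=O)[C@]23CC(c2ccc(C#N)cc2)N(c2ccccc2)O3)[C@]2(C)C(=O)C=C[C@@]12O` gives 2.94

For the measured compounds named here, in a physicochemical assay for lipophilicity (a lower number here means a more polar compound, a higher number a more lipophilic compound), compound 2 gives 2.94, the highest of the two numbers so far, and compound 1 sits well lower at 0.932, a gap beyond the usual scatter. Compounds 1 and 2 differ in several places at once, so the two numbers show only where each stands, not what any single change does.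

Compound 3 `C[C@H]1CC[C@@H]2[C@@H](OC(=O)[C@]23CC(c2ccccc2F)N(c2ccccc2)O3)[C@]2(C)C(=O)C=C[C@@]12O` is not yet measured. It differs from compound 2 in one place: 2-fluorophenyl in place of 4-cyanophenyl on a saturated ring carbon. Going by the values given here, no single-change step between measured compounds is available here, so the size of this step cannot be read off from the data. The counted difference shows that the leaving group carried one hydrogen-bond acceptor in its nitrile and the entering group carries none, so a moderate rise in this assay is expected, of about a number 0.61 log units higher from compound 2 to compound 3 (beyond the scatter). On that basis compound 3 is estimated to reach 3.55, with a likely range from 3.1 to 4.1.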

Compound 3, partition coefficient: 3.35
The estimate for compound 3 lay 0.20 log units above the measured number; the measured number falls inside the stated range.
By their numbers in this assay, from the lowest: compound 1; then compound 2; then compound 3.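

For the compounds shown here, compounds 1 and 2 differ in several places at once, so this is the first step that isolates a single change on the pendant ring: in this assay, putting 2-fluorophenyl in place of 4-cyanophenyl on the saturated ring carbon gives a number 0.41 log units higher from compound 2 to compound 3 (beyond the scatter). The change at this position therefore moves the read-out measurably, but it is not a clean swap of one atom group for another, since the two group names show that both the substituent and its number on the phenyl ring differ, and the nitrile's hydrogen-bond acceptor leaves with it. No measurement shown gives a reason for the step.

Still open, as far as these compounds go, is how much of the step belongs to the substituent itself and how much to its place on the ring, a split that 4-fluorophenyl or 2-cyanophenyl on the same saturated ring carbon could begin to show. Also open, from the compounds shown here alone, is where a group of another kind, such as 4-aminophenyl or 4-carboxyphenyl, would fall in this assay at this position.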